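This account rests on a few compounds, and the source may have more. Where it says the series, first, only, none or still open, it means among the compounds named here.

The measured compounds in an in vitro ADME assay on microsomes from liver (Mus musculus) for metabolic stability; on this read-out lower numbers stand for slow clearance and higher numbers for fast clearance:

Compound 1, `COCc1nc2nc(C)cc(Nc3ccc(S(F)(F)(F)(F)F)cc3)n2n1`, gives 14.3 mL.min-1.g-1.
Compound 2, `COCc1nc2nc(C)cc(Nc3ccc(C(F)(F)F)cc3)n2n1`, gives 13.3 mL.min-1.g-1.
Compound 3, `Cc1cc(Nc2cccc(Cl)c2)n2nc(C(C)(F)F)nc2n1`, gives 72.2 mL.min-1.g-1.

Compound 2 holds the lowest of the three numbers in this assay, but its value and that of compound 1 lie within the scatter of each other, so no order between them can be read; only compound 3 stands clearly apart, with a higher number beyond the scatter. The unmeasured compound 4, `CCc1nc2nc(C)cc(Nc3ccc(C(F)(F)F)cc3)n2n1`, differs from compound 2 in one place: methyl in place of methoxy on a saturated chain carbon bound to an aromatic carbon. Going by the values given here, no measured step touches this part of the molecule. Among the compounds with values here, the single step between compounds differing in one place, a 1.1-fold lower number from compound 1 to compound 2 (0.03 log units; within the scatter), concerns a different group on an aromatic carbon and moves nothing beyond the scatter. Compound 3 differs from compound 2 in more than one place, so its higher number cannot be tied to any single change. With nothing bearing directly on methyl in place of methoxy here, the reader should expect no step beyond the scatter for compound 4, that is a 1.2-fold higher number from compound 2 to compound 4 (0.08 log units; within the scatter). Compound 4 is therefore estimated at 16 mL.min-1.g-1, expected to fall between 7 mL.min-1.g-1 and 36 mL.min-1.g-1.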

Compound 4, intrinsic clearance in microsomes: 14.4 mL.min-1.g-1
Compound 4: middle estimate off by 1.1-fold (0.05 log units), on the high side; the range from low to high includes it.
By their numbers in this assay, from the lowest: compounds 2, 1 and 4 (each within the scatter of the next); then compound 3.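

In this assay, going by these compounds alone, methyl in place of methoxy on a saturated chain carbon bound to an aromatic carbon gives a 1.1-fold higher number from compound 2 to compound 4 (0.03 log units; within the scatter), so this part of the molecule now has a measured step of its own, which the earlier compounds did not provide. With the rest of the structure unchanged, methoxymethyl and ethyl cannot be told apart on this read-out, and removing the one hydrogen-bond acceptor of the methoxy group moves nothing beyond the scatter in this pair. No supporting data explain this result.

From the compounds shown here alone, whether an amine, a carboxylic acid or a longer chain at this place would also stay within the scatter remains open. Compound 3 differs from these compounds in more than one place, so which change lies behind the 72.2 mL.min-1.g-1 of compound 3 also remains open.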